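Moving the amino group on the anilino ring of a quinazoline series

A few compounds are considered here, and "the series" means these few. Any claim that something is new, unique, unknown or untested is made for them only; others in the source may bear on it.

Compound 1 `COc1ccccc1Nc1nc(-c2cccc(F)c2)nc2ccc(F)cc12` — > 50000 nM
Compound 2 `Fc1cccc(Nc2nc(-c3cccc(F)c3)nc3ccc(F)cc23)c1` — 47600 nM
Compound 3 `Nc1cccc(Nc2nc(-c3cccc(F)c3)nc3ccc(F)cc23)c1` — > 50000 nM

In a functional assay on MDA-MB-231 cells (Homo sapiens) for cytotoxicity, read by MTT assay, with a stated time of 48 h (on this read-out lower numbers stand for stronger inhibition and higher numbers for weaker inhibition), compound 1 gives > 50000 nM, which is a limit of the assay rather than a number. In this assay compound 2 gives 47600 nM. Compound 3 gives > 50000 nM, again a limit and not a number. Compound 3 therefore stands at the ceiling of what this assay reports, and the limit of > 50000 nM in this assay, at which 2 of the 3 values shown sit, shows that it shares that ceiling with compound 1. The step of an at least 1.0-fold higher number from compound 2 to compound 3 (0.02 log units; that floor lies within the scatter) is within the scatter, and the step that the two limits leave unreadable from compound 1 to compound 3 cannot be read.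

Compound 4 `Nc1ccccc1Nc1nc(-c2cccc(F)c2)nc2ccc(F)cc12` is the next compound, an isomer of compound 3: 2-aminophenyl in place of 3-aminophenyl on a nitrogen on an aromatic ring. For the measured compounds named here, the only step that exchanges one anilino ring for another between two readable points is an at least 1.0-fold lower number from compound 1 to compound 2 (0.02 log units; that floor lies within the scatter), and it is within the scatter. Going by the values given here, no measured step in this assay separates two such rings by more than the scatter, so compound 4 is expected to remain near the limit, with the step that the limit leaves unreadable from compound 3 to compound 4 expected to stay within the scatter. Compound 4 is accordingly estimated at 60000 nM, in a range from 25000 nM to 150000 nM.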

Compound 4, half-maximal inhibitory concentration: > 50000 nM
Compound 4 gave a limit, no number (the forecaster's own chance of this, stated with the estimate: 75%); the middle value is on the limit's open side.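

Moving the amino group from 3-aminophenyl to 2-aminophenyl on the nitrogen brings no number out of this assay: compound 4 gives > 50000 nM, which is a limit of the assay and not a number. For the compounds shown here, the only step to compound 4 that can be read is an at least 1.0-fold higher number from compound 2 to compound 4 (0.02 log units; that floor lies within the scatter), which lies within the scatter, while the steps that join compound 4 to compound 1 and compound 3 cannot be read. So both placings of the amino group shown here end at the same limit, which compound 1 also reaches, and this change gives no readable difference: the limit of > 50000 nM in this assay, at which 3 of the 4 values shown sit.

Going by these compounds, how far compound 1, compound 3 and compound 4 lie beyond that limit stays open, so any real difference among them remains hidden. On these data alone, it is also open whether a hydroxyl group or a carboxylic acid in place of the amino group on the aromatic carbon would give a value that can be read as a number.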